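The compounds below may be only part of what the source reports. "The series", "measured", "known", "first", "only" and "open" are said of these compounds alone.

Measured in a physicochemical assay for solubility, read by nephelometry; a higher number here means a more soluble compound, a lower number a less soluble compound:
- compound 1 `CC1(C)C(=O)N(c2ccc(SC(F)(F)F)cc2)C(=O)N1Cc1ccnc(C(=O)O)c1`: 0.142 ug/mL
- compound 2 `CC1(C)C(=O)N(c2ccc(SC(F)(F)F)cc2)C(=O)N1Cc1ccnc(NC2CCCCC2)c1`: < 0.025 ug/mL, a limit
- compound 3 `COc1ccc(CNc2cc(CN3C(=O)N(c4ccc(SC(F)(F)F)cc4)C(=O)C3(C)C)ccn2)cc1`: < 0.027 ug/mL, a limit

Compound 3 stands at a limit and not at a number: < 0.027 ug/mL. Compound 4 `CC(C)Nc1cc(CN2C(=O)N(c3ccc(SC(F)(F)F)cc3)C(=O)C2(C)C)ccn1` carries isopropyl in place of 4-methoxybenzyl on a nitrogen on an aromatic ring. The closest measured change, at the same place, is a step that the two limits leave unreadable from compound 2 to compound 3. Two further steps replace carboxy with a substituted amino group: an at least 5.6-fold lower number from compound 1 to compound 2 (0.75 log units; beyond the scatter) and an at least 5.2-fold lower number from compound 1 to compound 3 (0.72 log units; beyond the scatter). Compound 4 also carries a substituted amino group, so it is expected to remain at the low end of this assay. The expected change is an at least 1.1-fold higher number from compound 3 to compound 4 (0.04 log units; that floor lies within the scatter), with no step beyond the scatter anticipated. For compound 4 the estimated value is 0.03 ug/mL, with an expected range of 0.015 ug/mL to 0.1 ug/mL.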

Compound 4, solubility: < 0.023 ug/mL
Compound 4: a limit, no number (the forecaster's own chance of this, stated with the estimate: 60%); middle value at least 1.3-fold (0.11 log units) from the limit.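

Isopropyl, with no ring, stays at the low end of this assay as cyclohexyl and 4-methoxybenzyl do, so among these compounds a ring on this nitrogen is not required for that outcome. Isopropylamino in place of carboxy gives an at least 6.1-fold lower number from compound 1 to compound 4 (0.79 log units; beyond the scatter). Compound 4 stands at a limit, and the steps to it from compound 2 and compound 3 cannot be read.

No order among these three substituents on the nitrogen can be given. On these data alone, whether a hydroxyethyl group, or a longer chain ending in a carboxylic acid or an amine, would lift the read-out off the limit remains open.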